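A few compounds are considered here, and "the series" means these few. Any claim that something is new, unique, unknown or untested is made for them only; others in the source may bear on it.

Compound 2 `Oc1ccccc1-c1cc(-c2ccoc2)cc(-c2ccccc2O)n1` and compound 1 `Oc1ccccc1-c1cc(-c2ccco2)cc(-c2ccccc2O)n1` share one core and differ only in the furan ring. In a functional assay on T47D cells (Homo sapiens) for cytotoxicity, read by CCK-8 assay (a higher number here means a weaker inhibitor, a lower number a stronger inhibitor), compound 1 reaches only the assay limit of > 50000 nM. In this assay compound 2 likewise reaches only the limit of > 50000 nM. The step that the two limits leave unreadable from compound 1 to compound 2 therefore cannot be read, and the limit of > 50000 nM in this assay, at which 2 of the 2 values shown sit, holds for every value shown. Compound 3 `Oc1ccccc1-c1cc(-c2cccnc2)cc(-c2ccccc2O)n1` carries the change (pyridin-3-yl in place of furan-3-yl on an aromatic carbon). Among the compounds with values here, no measured step bears on this change, so the only guide is that both measured compounds sit at the limit. Compound 3 is therefore expected to remain at or near the limit, estimated at 60000 nM within 20000 nM to 200000 nM. The expected step that the limit leaves unreadable from compound 2 to compound 3 is thus estimated as none beyond the scatter.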

Compound 3, half-maximal inhibitory concentration: > 50000 nM
Compound 3 was reported as a limit; the forecaster's own chance of this, stated with the estimate: 80%; the middle value lies beyond the limit too.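

No step among compound 1, compound 2 and compound 3 can be read in this assay, as each gives only a limit: the limit of > 50000 nM in this assay, at which 3 of the 3 values shown sit.

The compounds shown leave open how far any of these three groups on the shared core affects potency.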